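Swapping trifluoromethyl for chloro on a diaryl urea

The source may hold more compounds than are shown below. What is called first, only, known or untested is meant among the compounds shown, and "the series" means these compounds.

Within the data shown here, compound 2 `COc1cc2cc(Oc3ccc(NC(=O)Nc4ccc(Cl)c(C(F)(F)F)c4)cc3)c(C)nc2cc1OC` gives 4550 nM in a functional assay on OVCAR-8 cells (Homo sapiens) for inhibition, read by sulforhodamine B assay, with a stated time of 48 h (on this read-out lower numbers stand for stronger inhibition of growth and higher numbers for weaker inhibition of growth), and is one of only two measured compounds. Compound 1 `COc1cc2cc(Oc3ccc(NC(=O)Nc4cccc(C(F)(F)F)c4)cc3)c(C)nc2cc1OC` gives 6280 nM in this assay, and the step of a 1.4-fold lower number from compound 1 to compound 2 (0.14 log units; within the scatter) leaves the two standing together. Compound 3 `COc1cc2cc(Oc3ccc(NC(=O)Nc4ccc(Cl)c(Cl)c4)cc3)c(C)nc2cc1OC` differs from compound 2 by chloro in place of trifluoromethyl on an aromatic carbon. Among the measured compounds shown here, no measured step touches this change directly; the only step available, a 1.4-fold lower number from compound 1 to compound 2 (0.14 log units; within the scatter), concerns another position and was small. Compound 3 is therefore expected to stay close to compound 2, with an estimated step of a 1.1-fold higher number from compound 2 to compound 3 (0.04 log units; within the scatter), giving 5000 nM with a range from 2500 nM to 10000 nM.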

Compound 3, concentration for total growth inhibition: 12900 nM
The estimate for compound 3 lay 2.6-fold (0.41 log units) below the measured number, outside the stated range (above it).
By their numbers in this assay, from the lowest: compounds 2 and 1 (each within the scatter of the next); then compound 3.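

This position responds to what sits on it: in this assay, chloro in place of trifluoromethyl gives a 2.8-fold higher number from compound 2 to compound 3 (0.45 log units; beyond the scatter), whereas the earlier step, a change at another position, stayed within the scatter. The comparison with the 3-(trifluoromethyl)phenyl compound points the same way, with a 2.1-fold higher number from compound 1 to compound 3 (0.31 log units; beyond the scatter). No measurement here explains why the number rises.

Still open, on these data alone, is how other groups on this carbon would compare, such as a nitrile or a methoxy group. Only trifluoromethyl and chloro can be compared there so far.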